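The source may hold more compounds than are shown below. What is called first, only, known or untested is meant among the compounds shown, and "the series" means these compounds.

Compound 1 `CCN1C(=O)C2(C(C#N)=C(N)Oc3cc4oc(-c5ccccc5)cc(=O)c4c(O)c32)c2cc(C)ccc21`: in a functional assay on NCI-H1299 cells (Homo sapiens) for antiproliferative activity, read by MTT assay, with a stated time of 48 h (a lower number here means a stronger inhibitor, a higher number a weaker inhibitor), compound 1 gives > 50000 nM, which is a limit of the assay and not a number.
Compound 2 `N#CC1=C(N)Oc2cc3oc(-c4ccccc4)cc(=O)c3c(O)c2C12C(=O)Nc1ccccc12`: compound 2 gives > 50000 nM, again a limit rather than a number.
Compound 3 `N#CC1=C(N)Oc2cc3oc(-c4ccccc4)cc(=O)c3c(O)c2C12C(=O)Nc1cc(Cl)ccc12`: compound 3 gives 16600 nM.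

For the measured compounds named here, compound 3 therefore holds the only actual number among the three; the other two results sit at the limit (the limit of > 50000 nM in this assay, at which 2 of the 3 values shown sit). Going by the values given here, the one measured step is an at least 3.0-fold lower number from compound 2 to compound 3 (0.47 log units; beyond the scatter), where a chloro group replaces a hydrogen on an aromatic carbon of the shared core.

Compound 4 `N#CC1=C(N)Oc2cc3oc(-c4ccccc4)cc(=O)c3c(O)c2C12C(=O)Nc1cc(Br)ccc12` differs from compound 3 by bromo in place of chloro on an aromatic carbon. Among the compounds with values here, no measured pair swaps one halogen for another, so the only step that bears on this change is an at least 3.0-fold lower number from compound 2 to compound 3 (0.47 log units; beyond the scatter), and it tells only that placing a halogen at this carbon moved the value, not how bromo compares with chloro. The expectation for compound 4 is therefore a step within the usual scatter, a 1.2-fold lower number from compound 3 to compound 4 (0.07 log units; within the scatter), with no clear direction. Compound 4 is estimated at 14000 nM, expected to fall between 6000 nM and 35000 nM.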

Compound 4, half-maximal inhibitory concentration: 14400 nM
Compound 4: middle estimate off by 1.0-fold (0.01 log units), on the low side; measured number inside the range.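

In this assay, exchanging chloro for bromo on this aromatic carbon makes no difference that can be told from the scatter: a 1.2-fold lower number from compound 3 to compound 4 (0.06 log units; within the scatter). Bromo also separates clearly from hydrogen, an at least 3.4-fold lower number from compound 2 to compound 4 (0.54 log units; beyond the scatter), so the earlier link between a halogen at this carbon and a lower number now rests on two halogens instead of one. Going by these compounds, compound 2 gives > 50000 nM, which is a limit of the assay and not a number, so the full size of that step stays unknown.

On these data alone, whether the same holds for a smaller halogen such as fluoro, or for a group that is not a halogen, such as methoxy or an amine, remains open. Also open, as far as these compounds go, is whether a halogen on another carbon of this ring would move the value in the same way.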